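Replacing 2,6-dichlorophenyl in compound 1: working notes

A few compounds are considered here, and "the series" means these few. Any claim that something is new, unique, unknown or untested is made for them only; others in the source may bear on it.

Going by the values given here, in a functional assay on HCT-116 cells (Homo sapiens) for antiproliferative activity, read by MTT assay, with a stated time of 48 h (on this read-out higher numbers stand for weaker inhibition and lower numbers for stronger inhibition), compound 1 `COc1cc(/C=C/C(C)=O)ccc1OCc1cn(-c2c(Cl)cccc2Cl)nn1` gives 2000 nM, the lower of the two numbers measured so far. Compound 2 `CCOC(=O)c1ccc(-n2cc(COc3ccc(/C=C/C(C)=O)cc3OC)nn2)cc1`, which carries a different group on the same aromatic nitrogen, gives 78900 nM, a gap beyond the scatter.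

Compound 3 `COc1cc(/C=C/C(C)=O)ccc1OCc1cn(-c2cc(F)cc(Br)c2)nn1` is still unmeasured. It has 3-bromo-5-fluorophenyl in place of 2,6-dichlorophenyl on an aromatic nitrogen, and the core of compound 1 stays the same.

Among the compounds with values here, no measured step isolates this replacement, so the expectation rests on thin evidence. Within the data shown here, compound 1 at 2000 nM holds the lower number, and the only other group tested on that nitrogen, in compound 2, comes with 78900 nM. A move towards weaker inhibition is therefore expected, though probably a smaller one than that gap. The estimated change is a 3.0-fold higher number from compound 1 to compound 3 (0.48 log units; beyond the scatter), modest but beyond the scatter. For compound 3 the expected value is 6000 nM, with an estimated range from 1500 nM to 30000 nM.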

Compound 3, half-maximal inhibitory concentration: 45400 nM
For compound 3 the middle estimate is 7.6-fold (0.88 log units) below the measured one; the whole stated range lies below it.
By their numbers in this assay, from the lowest: compound 1; then compounds 3 and 2 (each within the scatter of the next).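

In this assay, going by these compounds alone, the step of a 23-fold higher number from compound 1 to compound 3 (1.36 log units; beyond the scatter) is the first measured single change on this aromatic nitrogen, and it is large: 3-bromo-5-fluorophenyl does not keep the number of compound 1, although it matches 2,6-dichlorophenyl in heavy-atom count and neither group has a hydrogen-bond donor or acceptor. Compound 3 at 45400 nM and compound 2 at 78900 nM lie within the scatter of each other, so of the three groups on this nitrogen, only 2,6-dichlorophenyl goes with a number beyond the scatter from both others. No measurement on hand offers an explanation for the step.

The change from compound 1 to compound 3 alters both the halogens and the positions they occupy on the phenyl ring, so the compounds shown cannot separate these two contributions. A 3,5-dichlorophenyl group would keep the chlorine atoms while changing their positions, and 2,6-dibromophenyl or an unsubstituted phenyl group would address the role of the halogens themselves.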